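From phenyl to fluoro on the shared core

This account rests on a few compounds, and the source may have more. Where it says the series, first, only, none or still open, it means among the compounds named here.

In an ADME assay on J774 cells (Mus musculus) for cytotoxicity (a higher number here means that more compound is needed for the effect, a lower number that less compound is needed), compound 2 (`COC(=O)c1c[nH]c2cc(-c3ccccc3)ccc2c1=O`) gives > 20000 nM as a limit of the assay and not a number. Compound 1 (`COC(=O)c1c[nH]c2cc(Oc3ccccc3)ccc2c1=O`) gives 9120 nM in the same this assay reading. Going by the values given here, the one measured step shows an at least 2.1-fold higher number from compound 1 to compound 2 (0.34 log units; beyond the scatter) and it ends at the limit (the limit of > 20000 nM in this assay, at which 1 of the 2 values shown sits). Compound 3 (`COC(=O)c1c[nH]c2cc(F)ccc2c1=O`) follows from compound 2 by fluoro in place of phenyl on an aromatic carbon on the same carbon. That measured step points to a high number again, so the expected step that the limit leaves unreadable from compound 2 to compound 3 is estimated to stay small in this assay and no large fall is expected. The estimate for compound 3 is 25000 nM with an expected range (10000 nM to 60000 nM).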

Compound 3, half-maximal effective concentration: > 20000 nM
Compound 3 ended at the assay's limit; the forecaster's own chance of this, stated with the estimate: 65%; the middle value does not contradict the limit.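

Fluoro in place of phenoxy on this aromatic carbon gives an at least 2.1-fold higher number from compound 1 to compound 3 (0.34 log units; beyond the scatter). A group without a ring thus ends at the same limit as phenyl in this assay, and among the three groups shown only phenoxy gives a readable number. The step from compound 2 to compound 3 cannot be read, because both compounds stand at a limit: the limit of > 20000 nM in this assay, at which 2 of the 3 values shown sit.

As far as these compounds go, how far compound 2 and compound 3 lie past that limit remains open. So does whether an amine or a carboxylic acid on this carbon would give a readable number, as phenoxy does.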